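An aryl amide variant in the rat paw edema test

The compounds below may be only part of what the source reports. "The series", "measured", "known", "first", "only" and "open" are said of these compounds alone.

Compound 3 `COc1ccc(-n2nc(C(=O)Nc3ccccc3C)nc2-c2cc(OC)c(OC)c(OC)c2)cc1` stands lowest of a small series measured in a functional assay on the whole organism for inhibition, with Rattus norvegicus as the target, read by paw edema, with stated times of 30 min and 3 h, at a dose of 0.28 mmol/kg by the oral route; a lower number here means less inhibition, a higher number more inhibition at the dose given (going by the name of the read-out). Compound 1 `COc1ccc(-n2nc(C(N)=O)nc2-c2cc(OC)c(OC)c(OC)c2)cc1` gives 92%, and compound 2 `CCNC(=O)c1nc(-c2cc(OC)c(OC)c(OC)c2)n(-c2ccc(OC)cc2)n1` gives 88%, whereas compound 3 gives 64%. Its steps from the others read a number 28 percentage points lower from compound 1 to compound 3 (beyond the scatter) and a number 24 percentage points lower from compound 2 to compound 3 (beyond the scatter), while between the two higher compounds there is a number 4 percentage points lower from compound 1 to compound 2 (within the scatter). Compound 4 `COc1ccc(-n2nc(C(=O)Nc3ccc(C(=O)O)cc3)nc2-c2cc(OC)c(OC)c(OC)c2)cc1` alters compound 3 in one place: 4-carboxyphenyl in place of 2-methylphenyl on an amide-type nitrogen. For the measured compounds named here, both steps that bear on this position end at compound 3 and are modest; no measured pair sets one aryl group on the amide nitrogen against another. Compound 4 is therefore expected to stay near compound 3, with a number 2 percentage points lower from compound 3 to compound 4 (within the scatter) expected to fall within the scatter. Compound 4 is estimated at 62%, ranging from 42% to 82%.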

Compound 4, a percentage reported as inhibition, in the whole organism at one dose (the size of the read-out at that dose, not a potency): 95%
Compound 4: the middle estimate sits 33 percentage points below what was measured, and the stated range ends below it.
By their numbers in this assay, from the lowest: compound 3; then compounds 2, 1 and 4 (each within the scatter of the next).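

In this assay, for the compounds shown here, the identity of the aryl group on the amide-type nitrogen matters: a number 31 percentage points higher from compound 3 to compound 4 (beyond the scatter) is the first comparison of one aryl group with another, and it shows that an aryl amide need not sit low. The steps of a number 7 percentage points higher from compound 2 to compound 4 (within the scatter) and a number 3 percentage points higher from compound 1 to compound 4 (within the scatter) show no separation from the ethyl and hydrogen compounds, so the lower value belongs to compound 3 and not to aryl amides as a class. Nothing available explains this difference.

The compounds shown leave open whether the carboxylic acid, its place on the ring or the loss of the methyl carries the change. A plain phenyl or a 4-methylphenyl group on the same nitrogen would help separate these.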